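4-Chlorophenyl to 4-methylphenyl on the sulfonyl sulfur

The compounds below may be only part of what the source reports. "The series", "measured", "known", "first", "only" and "open" are said of these compounds alone.

Of the compounds shown here, two with the shared core have numbers so far in a functional assay on U-87MG ATCC cells for cytotoxicity against U-87 MG (Homo sapiens), read by MTT assay, with a stated time of 72 h; on this read-out lower numbers stand for stronger inhibition and higher numbers for weaker inhibition. Compound 1 (`CCN(CC)CCNC(=O)Nc1nc2ccc(-c3cnc(OC)c(NS(=O)(=O)c4ccc(F)cc4F)c3)cn2n1`) gives 1060 nM, and compound 2 (`CCN(CC)CCNC(=O)Nc1nc2ccc(-c3cnc(OC)c(NS(=O)(=O)c4ccc(Cl)cc4)c3)cn2n1`) gives 760 nM. The measured step is a 1.4-fold lower number from compound 1 to compound 2 (0.14 log units; within the scatter), so compound 2 cannot be separated from compound 1 on these numbers.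

The next compound is compound 3 (`CCN(CC)CCNC(=O)Nc1nc2ccc(-c3cnc(OC)c(NS(=O)(=O)c4ccc(C)cc4)c3)cn2n1`). Its difference from compound 2 is methyl in place of chloro on an aromatic carbon, para to a large group, which turns the 4-chlorophenyl into 4-methylphenyl.

Within the data shown here, only one measured step bears on this change, the swap of 2,4-difluorophenyl for 4-chlorophenyl on the same sulfonyl sulfur, and it stayed within the scatter. Among the measured compounds shown here, no measured pair compares chloro with methyl directly. From the compounds shown here alone, no step beyond the scatter is therefore expected in this assay, and the direction remains open.

The expected result is a 1.1-fold higher number from compound 2 to compound 3 (0.05 log units; within the scatter). Compound 3 is estimated at 850 nM, with an expected range from 380 nM to 1900 nM.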

Compound 3, half-maximal inhibitory concentration: 670 nM
The estimate for compound 3 lay 1.3-fold (0.10 log units) above the measured number; the measured number falls inside the stated range.
By their numbers in this assay, from the lowest: compounds 3, 2 and 1 (each within the scatter of the next).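

In this assay, the swap of 4-chlorophenyl for 4-methylphenyl now has a direct reading: methyl in place of chloro on the aromatic carbon gives a 1.1-fold lower number from compound 2 to compound 3 (0.05 log units; within the scatter). The comparison with the 2,4-difluorophenyl compound also holds for the new group, with a 1.6-fold lower number from compound 1 to compound 3 (0.20 log units; within the scatter), so the three aryl groups on the sulfonyl sulfur cannot be separated on these numbers, and this position has so far shown no step beyond the scatter. No independent measurement bears on this result.

The compounds shown do not settle whether a group of another kind on the same aromatic carbon, such as an amine, a carboxylic acid or a longer chain, would give a step beyond the scatter. From the compounds shown here alone, all three also share the diethylamino chain and the core, so the response to a change there, such as a morpholine in place of the diethylamino group, remains open.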